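The source may report more compounds than this note shows. Statements on the series, on what has been measured and on what is new or still open speak of the compounds shown alone.

Measured compounds:
- compound 1 `O=C(O)C12CC(CN3CCC[C@H](O[C@H](CO)c4cc(Cl)cc(Cl)c4)[C@@H]3c3ccccc3)(C1)C2`: 12000 nM
- compound 2 `COC(=O)c1ccc(CN2CCC[C@H](O[C@H](CO)c3cc(Cl)cc(Cl)c3)[C@@H]2c2ccccc2)c(C)c1`: 900 nM
- compound 3 `Cc1cc(C(=O)O)ccc1CN1CCC[C@H](O[C@H](CO)c2cc(Cl)cc(Cl)c2)[C@@H]1c1ccc(F)cc1`: 18000 nM

In an assay on isolated protein for activation of cGMP-dependent protein kinase 1 (Homo sapiens), read by ADP-Glo, with stated times of 30 min and 2 h, in the presence of a further agent that is not named here (a lower number here means that less compound is needed, a higher number that more compound is needed for the effect), compound 2 stands lowest of the three; compound 1 sits one large step above it, a 13-fold lower number from compound 1 to compound 2 (1.12 log units; beyond the scatter) when read the other way, and compound 3, with its value of 18000 nM, sits furthest away. Compound 4 `Cc1cc(C(=O)O)ccc1C(C)N1CCC[C@H](O[C@H](CO)c2cc(Cl)cc(Cl)c2)[C@@H]1c1ccccc1` is not yet measured. It differs from compound 2 by a group of 12 heavy atoms (10 carbon, 2 oxygen; one six-membered aromatic ring of carbon only) in place of a group of 12 heavy atoms (10 carbon, 2 oxygen; one six-membered aromatic ring of carbon only), on an amine nitrogen in a ring: the group that leaves is an ester with a methyl on the ring, the group that enters is a free acid with a methyl on the chain carbon attached to the ring nitrogen. For the measured compounds named here, no measured step changes exactly this; the one measured step, from compound 1 to compound 2, swaps a free-acid bearing group for this ester bearing group and gives a large drop, and compound 3, the other free acid, also shows a far higher number than compound 2, though it differs in two places. Both free acids here give much higher numbers than the ester, so a sizeable rise is expected for compound 4, an 8.9-fold higher number from compound 2 to compound 4 (0.95 log units; beyond the scatter), with wide uncertainty. Compound 4 is estimated at 8000 nM, between 1500 nM and 40000 nM.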

Compound 4, half-maximal effective concentration: 18000 nM
Compound 4: middle estimate off by 2.3-fold (0.35 log units), on the low side; the range from low to high includes it.
By their numbers in this assay, from the lowest: compound 2; then compounds 1, 3 and 4 (each within the scatter of the next).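

In this assay the group on the amine nitrogen in the ring proves highly sensitive to how its atoms are joined, with a 20-fold higher number from compound 2 to compound 4 (1.30 log units; beyond the scatter) even though the leaving and entering groups have the same count of heavy atoms. This single swap changes two features together, since a methyl ester becomes a free carboxylic acid and the methyl moves from the aromatic ring to the chain carbon attached to the ring nitrogen, and the data offer no explanation for the rise. Among the free acids, the aromatic group of compound 4 and the group with two four-membered rings of compound 1 are not separated, with a 1.5-fold higher number from compound 1 to compound 4 (0.18 log units; within the scatter) lying within the usual scatter.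

From the compounds shown here alone, how much of the large step belongs to the loss of the ester and how much to the moved methyl stays open, and a direct partner of compound 2 with the same ring methyl and a free carboxylic acid would separate the two. Also open, going by these compounds, is what a primary amide in place of the acid, or an ethyl group on that chain carbon, would do.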